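The source may report more compounds than this note shows. Statements on the series, on what has been measured and on what is new or still open speak of the compounds shown alone.

In a functional assay on CaEs17 cells (Homo sapiens) for inhibition, read by MTT assay (a lower number here means a stronger inhibitor, a higher number a weaker inhibitor), the three measured compounds gave the following numbers:

Compound 1 `C=C1C(=O)[C@@]23C(=O)OC[C@]4([C@@H](OC(C)=O)CCC(C)(C)[C@H]4C=O)[C@@H]2CC[C@H]1[C@H]3OC(=O)c1ccc(C(F)(F)F)cc1`: 9160 nM
Compound 2 `C=C1C(=O)[C@@]23C(=O)OC[C@]4([C@@H](OC(C)=O)CCC(C)(C)[C@H]4C=O)[C@@H]2CC[C@H]1[C@H]3OC(=O)c1ccc([N+](=O)[O-])cc1`: 1600 nM
Compound 3 `C=C1C(=O)[C@@]23C(=O)OC[C@]4([C@@H](OC(C)=O)CCC(C)(C)[C@H]4C=O)[C@@H]2CC[C@H]1[C@H]3OC(=O)CCCC`: 2850 nM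

Compound 3 stands second highest of the three. Its nearest neighbour is compound 2, with a 1.8-fold higher number from compound 2 to compound 3 (0.25 log units; within the scatter), a gap within the scatter. Its furthest is compound 1, with a 3.2-fold lower number from compound 1 to compound 3 (0.51 log units; beyond the scatter).

Compound 4 `C=C1C(=O)[C@@]23C(=O)OC[C@]4([C@@H](OC(C)=O)CCC(C)(C)[C@H]4C=O)[C@@H]2CC[C@H]1[C@H]3OC(=O)c1ccccc1Cl` is the unmeasured member. It differs from compound 3 in one place: 2-chlorophenyl in place of butyl on a carbonyl carbon.

For the measured compounds named here, two measured steps bear on this change, since both exchange an aryl group for butyl on the same carbonyl carbon: a 3.2-fold lower number from compound 1 to compound 3 (0.51 log units; beyond the scatter) and a 1.8-fold higher number from compound 2 to compound 3 (0.25 log units; within the scatter). The aryl esters therefore sit on both sides of compound 3, one beyond the scatter above it and one within the scatter below it, and the step between the two aryl esters themselves, a 5.7-fold lower number from compound 1 to compound 2 (0.76 log units; beyond the scatter), shows that the substituent on the ring matters. Going by the values given here, no measured step covers a chlorine on the ring, so the direction is uncertain. The expectation is a step of about a 1.2-fold higher number from compound 3 to compound 4 (0.09 log units; within the scatter) in this assay, that is, nothing clearly beyond the scatter. Compound 4 is estimated at 3500 nM, with a range from 1200 nM to 10000 nM.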

Compound 4, half-maximal inhibitory concentration: 600 nM
Compound 4: the middle estimate sits 5.8-fold (0.77 log units) above what was measured; the measured number lies below the stated range.
By their numbers in this assay, from the lowest: compound 4; then compounds 2 and 3 (each within the scatter of the next); then compound 1.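

In this assay the 2-chlorophenyl ester stands clear of every other group shown on this carbonyl carbon, with a 4.8-fold lower number from compound 3 to compound 4 (0.68 log units; beyond the scatter) and a 2.7-fold lower number from compound 2 to compound 4 (0.43 log units; beyond the scatter) and a 15-fold lower number from compound 1 to compound 4 (1.18 log units; beyond the scatter) all pointing the same way. For the compounds shown here, compound 4 is the first aryl ester here to lie beyond the scatter of butyl on the lower side, so an aromatic ring on this carbonyl carbon can go with a lower number than the open chain, although compound 1 goes against that and compound 2 stays within the scatter of compound 3. Nothing available here explains this drop.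

The compounds shown leave open whether the drop follows the chlorine itself or its place on the ring, which a 4-chlorophenyl or a 2-fluorophenyl ester would separate. Also open, going by these compounds, is how a chain longer than butyl, or an amine on the ring, would move the number.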